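Amino in place of chloro on the indazole-bearing urea core

This account rests on a few compounds, and the source may have more. Where it says the series, first, only, none or still open, it means among the compounds named here.

Measured compounds: compound 1 `Nc1nn(C(=O)Nc2ccc(Cc3ccccc3)cc2)c2ccccc12` with 2220 nM; compound 2 `Nc1nn(C(=O)Nc2ccc(Cc3ccccc3)cc2)c2ccc(Cl)cc12` with 283 nM.

For the measured compounds named here, in a functional assay on SK-MEL-5 cells (Homo sapiens) for antiproliferative activity, read by sulforhodamine B assay, with a stated time of 48 h (a lower number here means a stronger inhibitor of growth, a higher number a weaker inhibitor of growth), compound 2 gives the lowest of the two numbers seen, and its only neighbour is compound 1. Going by the values given here, the one measured step, a 7.8-fold lower number from compound 1 to compound 2 (0.89 log units; beyond the scatter), shows that a chloro on the six-membered aromatic ring of the shared core separates the two.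

Compound 3 `Nc1ccc2c(c1)c(N)nn2C(=O)Nc1ccc(Cc2ccccc2)cc1` carries amino in place of chloro on an aromatic carbon. Among the compounds with values here, no measured step contains an amino at this position, so the only guide is that a chloro on this carbon lowered the number against hydrogen. An amino is a different kind of substituent, and the gain seen with chloro cannot be assumed to carry over. The expected step of a 5.3-fold higher number from compound 2 to compound 3 (0.72 log units; beyond the scatter) is therefore a rise in the number, towards the value of compound 1. Compound 3 is estimated at 1500 nM, with a range from 400 nM to 6000 nM.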

Compound 3, concentration for 50% growth inhibition: 6520 nM
The estimate for compound 3 lay 4.3-fold (0.64 log units) below the measured number; the whole stated range lies below it.
By their numbers in this assay, from the lowest: compound 2; then compound 1; then compound 3.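

In this assay this aromatic carbon works in both directions, so the substituent decides whether the number falls or rises against hydrogen. Amino in place of hydrogen gives a 2.9-fold higher number from compound 1 to compound 3 (0.47 log units; beyond the scatter) and so does more than give up the gain seen with chloro, since compound 3 ends on the far side of compound 1. The exchange of chloro for amino thus amounts to a 23-fold higher number from compound 2 to compound 3 (1.36 log units; beyond the scatter) and spans the whole range seen in this small set, but nothing shown explains the difference between the two groups.

The compounds shown leave open whether other groups on this carbon, such as fluoro, bromo, methoxy or a carboxylic acid, would lower the number as chloro does or raise it as amino does. They also leave open whether a substituted amine, such as dimethylamino or an acetamide, would behave like amino itself.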